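Swapping the benzyl arm for a thiourea on the core

The source may hold more compounds than are shown below. What is called first, only, known or untested is meant among the compounds shown, and "the series" means these compounds.

Compound 1 `NC(=O)c1c(NC(=O)c2ccccc2Cl)sc2c1CCN(Cc1ccc(Cl)cc1)C2` carries a 2-chlorophenyl on a carbonyl carbon and a 4-chlorobenzyl on the ring amine nitrogen of the shared core. In a functional assay on MKN-74 cells (Homo sapiens) for antiproliferative activity, with a stated time of 24 h (a lower number here means a stronger inhibitor, a higher number a weaker inhibitor), compound 1 gives 18700 nM, the higher of the two plain numbers, while compound 3 `NC(=O)c1c(NC(=O)c2cccc([N+](=O)[O-])c2)sc2c1CCN(Cc1ccc(Cl)cc1Cl)C2` gives 16500 nM, a gap that lies within the scatter. Compound 2 `NC(=O)c1c(NC(=O)c2ccc(C(F)(F)F)cc2)sc2c1CCN(Cc1ccc(Cl)cc1)C2` reaches only the limit > 50000 nM in this assay. Among the compounds with values here, the single step measured in one place, an at least 2.6-fold higher number from compound 1 to compound 2 (0.42 log units; beyond the scatter), concerns the aryl on the carbonyl carbon and rests on (the limit of > 50000 nM in this assay, at which 1 of the 3 values shown sits). Compound 4 `NC(=O)c1c(NC(=O)c2ccccc2Cl)sc2c1CCN(C(=S)Nc1ccccc1Br)C2` instead alters the other arm: a group of 10 heavy atoms (7 carbon, 1 nitrogen, 1 sulfur, 1 bromine; one six-membered aromatic ring of carbon only) in place of a group of 8 heavy atoms (7 carbon, 1 chlorine; one six-membered aromatic ring of carbon only), on an amine nitrogen in a ring. Within the data shown here, no measured step touches that part of the core, so nothing among the measured compounds speaks for a gain or a loss there, and the 2-chlorophenyl amide stays in place. For compound 4 the step is therefore expected to be a 1.1-fold higher number from compound 1 to compound 4 (0.03 log units; within the scatter), none beyond the scatter. The estimate for compound 4 is 20000 nM, with a range from 6000 nM to 60000 nM.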

Compound 4, half-maximal inhibitory concentration: 10800 nM
The estimate for compound 4 lay 1.9-fold (0.27 log units) above the measured number; the measured number falls inside the stated range.
By their numbers in this assay, from the lowest: compounds 4, 3 and 1 (each within the scatter of the next). At a limit, above all of these: compound 2.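

In this assay, within the data shown here, the first measured change on the amine nitrogen in a ring gives a 1.7-fold lower number from compound 1 to compound 4 (0.24 log units; within the scatter) and so stays within the scatter. The 4-chlorobenzyl can therefore give way to the thiourea arm, with its added hydrogen-bond donor and acceptor, without a measurable change in this read-out while the 2-chlorophenyl amide stays in place. Nothing measured here explains why the two arms give values within the scatter of each other.

The compounds shown leave open whether this tolerance extends to a urea, an acetyl group or a free amine on that nitrogen. They also do not show whether the thiourea arm would behave the same way alongside the 4-(trifluoromethyl)phenyl or 3-nitrophenyl amides.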